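Chloro in place of fluoro: compound 2 to compound 3

The source may report more compounds than this note shows. Statements on the series, on what has been measured and on what is new or still open speak of the compounds shown alone.

Measured so far:
- compound 1 `C=C(CC(=O)Nc1ccc(F)cc1F)C(=O)Nc1ccc(F)cc1F`: 84700 nM
- compound 2 `C=C(CC(=O)Nc1cc(F)ccc1F)C(=O)O`: > 110000 nM (a limit of the assay, not a number)

In an ADME assay on MDCK cells (Canis lupus familiaris) for cytotoxicity, read by MTT assay, with a stated time of 72 h (on this read-out lower numbers stand for higher toxicity in this test and higher numbers for lower toxicity in this test), compound 2 is known only by a limit of the assay, > 110000 nM. Compound 1 gives a number in this assay, 84700 nM. The two compounds differ in more than one place, so this pair gives no measure of a single change.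

Compound 3 `C=C(CC(=O)Nc1cc(Cl)ccc1F)C(=O)O` has not yet been measured. It carries chloro in place of fluoro on an aromatic carbon, para to a fluoro group and meta to a group of 9 heavy atoms. Among the compounds with values here, no measured pair covers this change. No step beyond the usual scatter is expected, and neither direction is favoured. The expected step is a number no higher from compound 2 to compound 3 (the limit leaves the size open). This expectation rests on compound 2 and its limit of the assay, > 110000 nM. A report as a limit is also expected to be likely for compound 3. For compound 3 the estimate in this assay is 110000 nM, with an expected range from 60000 nM to 200000 nM.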

Compound 3, half-maximal cytotoxic concentration: > 110000 nM
Compound 3 ended at the assay's limit; the forecaster's own chance of this, stated with the estimate: 70%; the middle value lies on the limit itself.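

No step can be read between compound 2 and compound 3 in this assay; both compounds stand at the same limit of the assay, not at a number: the limit of > 110000 nM in this assay, at which 2 of the 3 values shown sit.

The compounds shown leave open whether chloro in place of fluoro on an aromatic carbon changes the value in this assay at all, and in which direction.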